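A few compounds are considered here, and "the series" means these few. Any claim that something is new, unique, unknown or untested is made for them only; others in the source may bear on it.

Compound 1 `CCC[S+]([O-])CCCCN=C=S`: 3910 nM
Compound 2 `CC(C)[S+]([O-])CCCCN=C=S`: 2050 nM
Compound 3 `[O-][S+](CCCCN=C=S)Cc1ccccn1`: 5350 nM

All three values come from a functional assay on HepG2 cells (Homo sapiens) for cytotoxicity, read by MTT assay, with a stated time of 72 h; a higher number here means a weaker inhibitor, a lower number a stronger inhibitor. Compound 1 lies within the scatter of both compound 2 and compound 3. Compound 4 `[O-][S+](CCCCN=C=S)Cc1ccco1` is the next entry, with furan-2-yl in place of ethyl on a saturated chain carbon bound to a sulfur.

Within the data shown here, the only measured step is a 1.9-fold lower number from compound 1 to compound 2 (0.28 log units; within the scatter), and it lies within the scatter. It is a different change, so it bears only loosely. Compound 3, at 5350 nM, also carries a ring at this place and stays within the scatter of compound 1. No step beyond the scatter is therefore expected in this assay, and the expected step is a 1.2-fold higher number from compound 1 to compound 4 (0.06 log units; within the scatter). For compound 4 the estimated value is 4500 nM, with an expected range of 2200 nM to 9000 nM.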

Compound 4, half-maximal inhibitory concentration: 3860 nM
The estimate for compound 4 lay 1.2-fold (0.07 log units) above the measured number, within the range that was stated.
By their numbers in this assay, from the lowest: compounds 2, 4, 1 and 3 (each within the scatter of the next, the first and the last beyond it).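

In this assay, furan-2-yl in place of ethyl on a saturated chain carbon bound to a sulfur gives a 1.0-fold lower number from compound 1 to compound 4 (0.01 log units; within the scatter). Among these compounds, this is the first step read at this place that brings in a five-membered aromatic ring with 1 hetero atom and a hydrogen-bond acceptor, and it stays within the scatter despite the larger group. No measurement at hand accounts for this result.

Still open, on these data alone, is whether an amine or a carboxylic acid at this place would give a step beyond the scatter.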